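This account rests on a few compounds, and the source may have more. Where it says the series, first, only, none or still open, it means among the compounds named here.

Among the compounds with values here, in a functional assay on T47D cells (Homo sapiens) for cytotoxicity, read by sulforhodamine B assay, with a stated time of 48 h (a lower number here means a stronger inhibitor, a higher number a weaker inhibitor), compound 2 `N=C(N)NS(=O)(=O)c1ccc(N/C=C\C(=O)c2cc3ccccc3oc2=O)cc1` gives 87600 nM, the only number at hand for this series; for compound 1 `CC(=O)NS(=O)(=O)c1ccc(N/C=C\C(=O)c2cc3ccccc3oc2=O)cc1` the entry there reads no result reported. Compound 3 `O=C(/C=C\Nc1ccc(S(=O)(=O)Nc2ccc3cn[nH]c3c2)cc1)c1cc2ccccc2oc1=O` differs from compound 2 by a group of 9 heavy atoms (7 carbon, 2 nitrogen; one five-membered aromatic ring with 2 hetero atoms, one six-membered aromatic ring of carbon only) in place of a group of 3 heavy atoms (1 carbon, 2 nitrogen; no ring), on a sulfonamide nitrogen. Within the data shown here, no measured pair shows the effect of such a change, so any expectation rests on compound 2 alone. A step toward a lower number, somewhat beyond the usual scatter, is expected for this change, estimated as a 2.9-fold lower number from compound 2 to compound 3 (0.47 log units; beyond the scatter). Compound 3 is therefore expected to give about 30000 nM in this assay, with a range from 5000 nM to 150000 nM.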

Compound 3, half-maximal inhibitory concentration: 96500 nM
Estimate against measurement, compound 3: 3.2-fold (0.51 log units) below; measured number inside the range.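

On the sulfonamide nitrogen, 1H-indazol-6-yl in place of the ring-free group of compound 2 gives a 1.1-fold higher number from compound 2 to compound 3 (0.04 log units; within the scatter) in this assay. This first measured change at the position shows that a group of two aromatic rings and a group with no ring cannot be told apart in this read-out. No measurement available bears on an explanation of this result.

Steps involving compound 1 cannot be read, as it has no number. From the compounds shown here alone, whether a phenyl ring or a carboxylic acid on this nitrogen would give a step beyond the scatter remains open.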